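This account rests on a few compounds, and the source may have more. Where it says the series, first, only, none or still open, it means among the compounds named here.

Compound 1 `CCCc1cc(N2CCCCC2)c2cc(NC(=O)/C=C/c3ccc(C(F)(F)F)cc3)ccc2n1`: > 4000 nM
Compound 2 `CC(C)c1cc(N)c2cc(NC(=O)/C=C/c3ccc(C(F)(F)F)cc3)ccc2n1`: 2.1 nM

Of the compounds shown here, two have so far been measured in an assay on isolated protein for displacement of a labelled ligand from melanin-concentrating hormone receptor 1 (Homo sapiens); on this read-out higher numbers stand for weaker inhibition and lower numbers for stronger inhibition. Compound 2 gives 2.1 nM. Compound 1 gives > 4000 nM. For compound 1 this is a limit of the assay and not a number; it stands at the limit of > 4000 nM in this assay, at which 1 of the 2 values shown sits. Compound 1 therefore sits at the weak end of what is known, and compound 2 at the strong end. Compound 3 `CCCc1cc(NC2CCC2)c2cc(NC(=O)/C=C/c3ccc(C(F)(F)F)cc3)ccc2n1` has not yet been measured. It differs from compound 1 in one place: cyclobutylamino in place of piperidin-1-yl on an aromatic carbon The step from compound 1 to compound 3 is expected to be large and toward stronger inhibition, because compound 2 gives 2.1 nM while carrying an amino group on the shared core. Compound 1, by contrast, reaches only a limit of the assay. Compound 3 is expected to give 20 nM, within 3 nM to 200 nM, a step of an at least 200-fold lower number from compound 1 to compound 3 (2.30 log units; beyond the scatter).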

Compound 3, half-maximal inhibitory concentration: 18 nM
Compound 3: the middle estimate sits 1.1-fold (0.05 log units) above what was measured, within the range that was stated.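

Replacing piperidin-1-yl with cyclobutylamino opposite the ring nitrogen gives an at least 220-fold lower number from compound 1 to compound 3 (2.34 log units; beyond the scatter) in this assay, so inhibition at this position depends strongly on which group the shared core carries. The step cannot be read as an exact size because compound 1 stands at a limit of the assay: the limit of > 4000 nM in this assay, at which 1 of the 3 values shown sits. The entering group brings a hydrogen-bond donor that piperidin-1-yl lacks and a four-membered ring in place of a six-membered one, and this single pair cannot separate those two differences.

A cyclohexylamino group would keep the donor with a six-membered ring, while pyrrolidin-1-yl would have no donor, so either could help to tell the two differences apart. On these data alone, it also remains open how far the amine can grow at this position, for instance to a longer open chain such as n-butylamino, on the core with its propyl group.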